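Chloro to methyl on the aryl ring of an mGlu5 modulator

The compounds below may be only part of what the source reports. "The series", "measured", "known", "first", "only" and "open" are said of these compounds alone.

Measured in an assay on HEK293 cells for negative allosteric modulation of metabotropic glutamate receptor 5 (Homo sapiens), read by FLIPR; on this read-out lower numbers stand for stronger inhibition and higher numbers for weaker inhibition:
Compound 1 `O=C(c1ccc(F)cc1)N1CC(c2nc(-c3cccc(Cl)c3)no2)C1` gives 4000 nM.
Compound 2 `O=C(c1cccc(F)c1)N1CC(c2nc(-c3cccc(Cl)c3)no2)C1` gives 780 nM.
Compound 3 `O=C(N1CCCCCC1)N1CC(c2nc(-c3cccc(Cl)c3)no2)C1` reaches only the assay's limit, > 10000 nM.

Compound 2 gives the lowest number of the two measured, with compound 1 next, a 5.1-fold lower number from compound 1 to compound 2 (0.71 log units; beyond the scatter). Compound 4 `Cc1cccc(-c2noc(C3CN(C(=O)c4cccc(F)c4)C3)n2)c1` differs from compound 2 by methyl in place of chloro on an aromatic carbon. Every measured step alters the group on the carbonyl carbon instead: a 5.1-fold lower number from compound 1 to compound 2 (0.71 log units; beyond the scatter), an at least 2.5-fold higher number from compound 1 to compound 3 (0.39 log units; beyond the scatter) and an at least 12-fold higher number from compound 2 to compound 3 (1.10 log units; beyond the scatter). The chloro position is untouched by any of them, so there is no direct guide. Swapping chloro for methyl is expected to give no step beyond the scatter, a 1.4-fold higher number from compound 2 to compound 4 (0.15 log units; within the scatter). Compound 4 is therefore estimated at 1100 nM, between 400 nM and 3200 nM.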

Compound 4, half-maximal inhibitory concentration: 2100 nM
Estimate against measurement, compound 4: 1.9-fold (0.28 log units) below; the measured number falls inside the stated range.
By their numbers in this assay, from the lowest: compound 2; then compounds 4 and 1 (each within the scatter of the next). At a limit, above all of these: compound 3.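

In this assay the aryl end of the molecule also matters: methyl in place of chloro gives a 2.7-fold higher number from compound 2 to compound 4 (0.43 log units; beyond the scatter) even though a single heavy atom is exchanged for another single heavy atom. The earlier compounds shown here varied only the group on the carbonyl carbon, so this step alone shows that the 3-chlorophenyl group responds to change. Still open, as far as these compounds go, is how fluoro, methoxy or nitrile would behave at this position, and whether the step holds with 4-fluorophenyl on the carbonyl carbon. Nothing measured here accounts for the step.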